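Chloro for hydrogen on the aryl piperazine of compound 1

The source may hold more compounds than are shown below. What is called first, only, known or untested is meant among the compounds shown, and "the series" means these compounds.

Compound 1 `c1ccc(N2CCN(CCCCOc3ccc4c(c3)CCC4)CC2)cc1` gives 50% in a functional assay on the whole organism for inhibition, with Mus musculus as the target, at a dose of 25 mg/kg by the oral route (on this read-out lower numbers stand for less inhibition and higher numbers for more inhibition at the one dose given (going by the name of the read-out)), the higher of the two numbers recorded. Compound 2 `Fc1cccc(N2CCN(CCCOc3ccc4c(c3)CCC4)CC2)c1` gives 42% in this assay, and the two values lie within the scatter of each other, so no order between them can be read. Among the measured compounds shown here, compound 2 also carries a shorter chain and a different halogen, so no single step connects it to compound 1.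

Compound 3 `Clc1cccc(N2CCN(CCCCOc3ccc4c(c3)CCC4)CC2)c1` differs from compound 1 in one place: chloro in place of hydrogen on an aromatic carbon. For the measured compounds named here, no pair of measured compounds shows the effect of this change, and the one halogenated analogue, compound 2, sits within the scatter of compound 1. The step from compound 1 to compound 3 is therefore expected to be small, no change at the digits printed from compound 1 to compound 3 (within the scatter), with no direction beyond the scatter. Compound 3 is estimated to give 50% in this assay, between 30% and 70%.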

Compound 3, a percentage reported as inhibition, in the whole organism at one dose (the size of the read-out at that dose, not a potency): 0%
For compound 3 the middle estimate is 50 percentage points above the measured one; the measured number lies below the stated range.
By their numbers in this assay, from the lowest: compound 3; then compounds 2 and 1 (each within the scatter of the next).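

In this assay, among the compounds shown here, the change from phenyl to 3-chlorophenyl gives a step of a number 50 percentage points lower from compound 1 to compound 3 (beyond the scatter), the first step in this set that isolates a single change. It shows that this place on the ring is not neutral for the read-out at the one dose given: a single chlorine, the only heavy atom added, separates compound 1 from compound 3 , which gives 0% in this assay. Nothing available explains why this one atom has so large an effect.

From the compounds shown here alone, whether a methyl or methoxy group at this same place would also bring the read-out down remains open. Going by these compounds, it is equally open whether chloro on another carbon of that ring, or a longer chain alongside the chloro, would give a step of similar size.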